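This account rests on a few compounds, and the source may have more. Where it says the series, first, only, none or still open, it means among the compounds named here.

Of the compounds shown here, three have been measured in a functional assay on MCF7 cells (Homo sapiens) for antiproliferative activity, read by sulforhodamine B assay, with a stated time of 72 h, tested at 30 uM; a lower number here means a stronger effect, a higher number a weaker effect of the compound at the concentration tested. Compound 1 `COc1cc(Br)cc(/C=C/C(=O)c2ccccc2)c1O` gives 28.1% in this assay, compound 2 `COc1cc(Br)cc(/C=C/C(=O)c2ccc(Cl)cc2)c1O` gives 28%, and compound 3 `COc1cc(Br)cc(/C=C/C(=O)c2ccc(C)cc2)c1O` gives 61.5%. The step of a number 0.1 percentage points lower from compound 1 to compound 2 (within the scatter) leaves compound 1 and compound 2 within the scatter of each other, whereas the step of a number 33.4 percentage points higher from compound 1 to compound 3 (beyond the scatter) and the step of a number 33.5 percentage points higher from compound 2 to compound 3 (beyond the scatter) are both large. Compound 3 therefore stands highest of the three numbers, the weakest effect at the concentration tested, with compound 1 nearest and compound 2 furthest.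

Compound 4 `Cc1ccc(C(=O)/C=C/c2cc(Br)ccc2O)cc1` differs from compound 3 in one place: hydrogen in place of methoxy on an aromatic carbon. None of the three measured steps concerns this change; all three are exchanges at a different aromatic carbon, and the methyl group of compound 3 remains in compound 4. The measured steps thus give no direct guide to the change from compound 3 to compound 4, and the only point of reference is that compound 3, which carries the methyl group, gives 61.5% in this assay. Compound 4 is expected to stay close to compound 3, with a step of a number 3.5 percentage points higher from compound 3 to compound 4 (within the scatter) that is expected to lie within the scatter. Compound 4 is therefore estimated at 65%, with a range from 40% to 90%.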

Compound 4, a percentage reported as activity, at one concentration (the size of the read-out at that concentration, not a potency): 31.8%
Estimate against measurement, compound 4: 33.2 percentage points above; measured number outside the range, below it.
By their numbers in this assay, from the lowest: compounds 2, 1 and 4 (each within the scatter of the next); then compound 3.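

In this assay, within the data shown here, the exchange of methoxy for hydrogen on the aromatic carbon ortho to a hydroxy group and meta to a bromo group gives a number 29.7 percentage points lower from compound 3 to compound 4 (beyond the scatter), which shows that this position, untouched by the earlier steps, also bears on the read-out. The methyl group stands on both sides of this step, so its presence does not by itself fix a high number in this assay: what occupies the position ortho to the hydroxy group counts as well. Nothing available here accounts for the size or direction of this step.

As far as these compounds go, what the same exchange does when hydrogen or chloro stands in place of the methyl group remains open, so it cannot be said whether the size of this step depends on the methyl group. Also open, from the compounds shown here alone, is how the read-out would respond at this same position to an amine, to an ethoxy group with its longer chain, or to a fluoro group, since only methoxy and hydrogen are compared there.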